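A few compounds are considered here, and "the series" means these few. Any claim that something is new, unique, unknown or untested is made for them only; others in the source may bear on it.

Readings in an assay for inhibition of phosphodiesterase 1 (Bos taurus), read by cGMP accumulation (a higher number here means a weaker inhibitor, a lower number a stronger inhibitor), for the measured members of the series:

compound 1, `Nc1nc(O)c2ncn([C@@H]3C=C4C[C@](CC(=O)O)(C(=O)O)O[C@H]4[C@H]3O)c2n1`: 1000 nM
compound 2, `O=C(O)C[C@]1(C(=O)O)C[C@@H]2C[C@@H](n3cnc4c(O)ncnc43)C[C@@H]2O1`: 9000 nM
compound 3, `Nc1nc(Cl)c2ncn([C@@H]3C[C@@H]4C[C@H](C(=O)O)O[C@@H]4C3)c2n1`: 29000 nM

Compound 3 holds the highest number of the three in this assay, so it is the weakest inhibitor measured. Its nearest neighbour is compound 2, whose number is lower by a margin beyond the scatter; compound 1 lies furthest off, with a markedly lower number again. Compound 3 is also the only one of the three whose core carries a chlorine substituent in place of a hydroxyl.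

Compound 4, `Nc1nc(Cl)c2ncn([C@@H]3C[C@H]4C[C@@H](C(=O)O)O[C@H]4C3)c2n1`, is the next candidate for this assay. It keeps every atom and bond of compound 3: the two compounds have the same atoms and bonds and differ only in configuration as drawn: 3 of 4 stereo elements differ; a stereocentre at a saturated ring carbon is drawn R in compound 3 and S in compound 4; a stereocentre at a saturated ring carbon is drawn R in compound 3 and S in compound 4; a stereocentre at a saturated ring carbon is drawn R in compound 3 and S in compound 4. Only one stereo element is shared; the rest of the saturated ring framework is redrawn in the opposite sense.

For the measured compounds named here, no pair of measured compounds in this set differs by configuration alone, so there is no measured step on which to anchor the change. With three of four stereo elements inverted, a shift beyond the scatter in either direction is plausible, and a loss of inhibition is the more common outcome for such a rearrangement of a nucleoside-like scaffold; the expected step is a 1.6-fold higher number from compound 3 to compound 4 (0.19 log units; within the scatter) toward a higher number. Compound 4 is accordingly estimated at 45000 nM, within a range of 8000 nM to 250000 nM.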

Compound 4, half-maximal inhibitory concentration: 42000 nM
Compound 4: middle estimate off by 1.1-fold (0.03 log units), on the high side; the range from low to high includes it.
By their numbers in this assay, from the lowest: compound 1; then compound 2; then compounds 3 and 4 (each within the scatter of the next).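

In this assay, inverting three of the four stereo elements gives a 1.4-fold higher number from compound 3 to compound 4 (0.16 log units; within the scatter), so the two compounds cannot be told apart by this read-out. For the compounds shown here, this is the first step that isolates configuration, as the earlier compounds offered no such pair, and the comparison is clean for one reason: the fact that compounds 3 and 4 differ only in the configuration as drawn. For this pair, the drawn sense at those three saturated ring carbons therefore carries no effect beyond the scatter, a finding that applies to compound 3 and compound 4 only and does not extend to compound 1 or compound 2.

The compounds shown leave open what inverting the one shared stereo element would do, and whether configuration would count for as little in the hydroxyl-bearing cores of compound 1 and compound 2. Also open, going by these compounds, is whether the same lack of separation would hold for a pair of stereoisomers with a methyl ester in place of the carboxylic acid, or with bromine in place of the chlorine.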